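The compounds below may be only part of what the source reports. "The series", "measured", "known", "first", "only" and "open" are said of these compounds alone.

The measured compounds are:

Compound 1, `CC1=C(C(=O)Nc2ccc(Br)cc2)C(c2ccc(Cl)cc2Cl)N=C(SCc2ccccc2)N1`: in a functional assay on the whole organism (artery, strain albino) with Rattus norvegicus as the target, with a stated time of 240 min, at a dose of 10 mg/kg by the oral route (a higher number here means more inhibition at the dose given (going by the name of the read-out), a lower number less inhibition), compound 1 gives 17.4%.
Compound 2, `CC1=C(C(=O)Nc2ccc(Br)cc2)C(c2ccc(Cl)cc2Cl)N=C(SCc2cccc(Cl)c2)N1`: in this assay compound 2 gives 15.9%.

Among the compounds with values here, compound 2 stands lowest of the two numbers, with compound 1 nearest; the single measured step, a number 1.5 percentage points lower from compound 1 to compound 2 (within the scatter), shows chloro replacing hydrogen on an aromatic carbon and does not separate the two compounds beyond the scatter.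

Compound 3, `CC1=C(C(=O)Nc2ccc(Br)cc2)C(c2ccc(Cl)cc2Cl)N=C(SCc2ccc(Cl)cc2)N1`, differs from compound 2 by 4-chlorophenyl in place of 3-chlorophenyl on a saturated chain carbon bound to a sulfur. Within the data shown here, no measured step moves a chlorine within a chlorophenyl ring, so only the step of a number 1.5 percentage points lower from compound 1 to compound 2 (within the scatter) bears on this change, and it was small. The change from compound 2 to compound 3 is therefore expected to give no step beyond the scatter in this assay, the expected step being a number 0.1 percentage points higher from compound 2 to compound 3 (within the scatter). For compound 3 the estimate in this assay is 16%, expected to fall between 5% and 28%.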

Compound 3, a percentage reported as inhibition, in the whole organism at one dose (the size of the read-out at that dose, not a potency): 32.3%
Estimate against measurement, compound 3: 16.3 percentage points below; measured number outside the range, above it.
By their numbers in this assay, from the lowest: compounds 2 and 1 (each within the scatter of the next); then compound 3.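

In this assay, the place of the chlorine on the benzyl group matters: going from 3-chlorobenzyl to 4-chlorobenzyl on the sulfur gives a number 16.4 percentage points higher from compound 2 to compound 3 (beyond the scatter), although the two compounds hold the same atoms. Chloro in place of hydrogen on the aromatic carbon of the benzyl group is also not silent in every case, as it gives a number 14.9 percentage points higher from compound 1 to compound 3 (beyond the scatter), so the small earlier step applies to the 3-chlorophenyl group and not to chloro on this ring in general. Nothing measured here accounts for the higher number of compound 3.

On these data alone, it remains open whether a 4-fluorobenzyl or 4-methoxybenzyl group on the sulfur would match 4-chlorobenzyl in this assay. As far as these compounds go, the effect of a 2-phenylethyl group, with its longer chain, on the sulfur also remains open.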